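Methyl in Place of Hydrogen: Compounds 1 to 4

A few compounds are considered here, and "the series" means these few. Any claim that something is new, unique, unknown or untested is made for them only; others in the source may bear on it.

Compound 1 `CCC(=O)Nc1ccc(S(=O)(=O)Oc2ccccc2I)cc1` gives 7200 nM in a functional assay on HT-1080 cells (Homo sapiens) for antiproliferative activity, read by sulforhodamine B assay, with a stated time of 48 h; on this read-out lower numbers stand for stronger inhibition and higher numbers for weaker inhibition. Compound 2 `CCCC(=O)Nc1ccc(S(=O)(=O)Oc2ccccc2I)cc1` gives 2000 nM. Compound 3 `CC(C)C(=O)Nc1ccc(S(=O)(=O)Oc2ccccc2C(C)C)cc1` gives 4900 nM.

The change methyl in place of hydrogen on a saturated chain carbon, two bonds along the chain from a carbonyl carbon brought a 3.6-fold lower number from compound 1 to compound 2 (0.56 log units; beyond the scatter). The difference between the core of compound 1 and the core of compound 3 is not broken down here. Compound 4 `CC(C)c1ccccc1OS(=O)(=O)c1ccc(NC(=O)C(C)(C)C)cc1` carries the change (methyl in place of hydrogen on a saturated chain carbon bound to a carbonyl carbon and two saturated chain carbons); this is the same kind of change as that from compound 1 to compound 2, though the place differs: there the carbon is two bonds along the chain from a carbonyl carbon, here it is bound to a carbonyl carbon and two saturated chain carbons. Beside a 3.6-fold lower number from compound 1 to compound 2 (0.56 log units; beyond the scatter), the step from compound 3 to compound 4 is expected to be a 2.0-fold lower number from compound 3 to compound 4 (0.29 log units; within the scatter), a smaller step. Among the measured compounds shown here, the place of the change is not the same, and no measured pair shows the change at that place. Compound 4 is estimated at 2500 nM in this assay, between 1000 nM and 7000 nM.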

Compound 4, half-maximal inhibitory concentration: 11000 nM
For compound 4 the middle estimate is 4.4-fold (0.64 log units) below the measured one; the measured number lies above the stated range.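

The change brought a 2.2-fold higher number from compound 3 to compound 4 (0.35 log units; beyond the scatter), so the step seen on the core of compound 1 did not carry over to the core of compound 3. Set side by side in this assay, the two steps run in opposite directions: the same change on two cores in this assay, a 3.6-fold lower number (0.56 log units; beyond the scatter) from compound 1 to compound 2 and a 2.2-fold higher number (0.35 log units; beyond the scatter) from compound 3 to compound 4, 8.1-fold (0.91 log units) apart, beyond the scatter of two such steps

Among the compounds shown here, this does not show that the core alone decides the outcome, as the change also sits at a different place in each pair and each core offers only one pair.

As far as these compounds go, it remains open how a cyclopropyl group or a longer chain in place of the tert-butyl would read on the core of compound 3. Also open, from the compounds shown here alone, is whether the step from isopropyl to tert-butyl would keep its direction on the core of compound 1.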